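Hydroxy to Methyl on the Aryl Ring of a Thiazolidinone

A few compounds are considered here, and "the series" means these few. Any claim that something is new, unique, unknown or untested is made for them only; others in the source may bear on it.

Measured compounds:
compound 1 `O=C1CSC(c2c(Cl)cccc2Cl)N1CCN1CCCCC1`, 100%
compound 2 `O=C1CSC(c2cccc(O)c2)N1CCN1CCCCC1`, 100%
compound 3 `O=C1CSC(c2ccc(O)cc2)N1CCN1CCCCC1`, 100%

Of the compounds shown here, three sharing the core of compound 1 have been tested in an ADME assay on Vero cells (Chlorocebus sabaeus) for cytotoxicity, read by neutral red uptake, tested at 25 ug/mL; on this read-out lower numbers stand for a stronger effect and higher numbers for a weaker effect at the one concentration tested. Compound 1 gives 100%, compound 2 gives 100%, and compound 3 gives 100%, so all three sit together at the weak end of the read-out. Within the data shown here, the one single-point step among them, no change at the digits printed from compound 2 to compound 3 (within the scatter), moves 4-hydroxyphenyl in place of 3-hydroxyphenyl on a saturated ring carbon and leaves the read-out where it was. Among the measured compounds shown here, compound 3 therefore stands level with compound 1 and compound 2, with no step among the three beyond the scatter.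

The next compound, compound 4 `Cc1ccc(C2SCC(=O)N2CCN2CCCCC2)cc1`, differs from compound 3 by methyl in place of hydroxy on an aromatic carbon. For the measured compounds named here, no measured step exchanges hydroxy for methyl, so the bearing of the earlier steps is indirect: the step from compound 2 to compound 3 was flat, and compound 1, carrying a quite different aryl group, reads the same as compound 2 and compound 3. On that basis compound 4 is expected to read much as compound 3 does, with a step of a number 2 percentage points lower from compound 3 to compound 4 (within the scatter). The estimate for compound 4 in this assay is 98%, within a range from 85% to 100%.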

Compound 4, a percentage reported as activity, at one concentration (the size of the read-out at that concentration, not a potency): 100%
Compound 4: the middle estimate sits 2 percentage points below what was measured; low and high end bracket the measured number.
By their numbers in this assay, from the lowest: compounds 1, 2, 3 and 4 (each within the scatter of the next).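

In this assay, methyl in place of hydroxy on an aromatic carbon, para to a large group, exchanges one kind of group for another at this position and gives no change at the digits printed from compound 3 to compound 4 (within the scatter), so the read-out holds without the hydrogen-bond donor and hydrogen-bond acceptor counted on hydroxy. The wider change to 4-methylphenyl in place of 3-hydroxyphenyl gives no change at the digits printed from compound 2 to compound 4 (within the scatter), so neither of the two hydroxyphenyl groups reads apart from 4-methylphenyl in this set. Nothing available bears on why the read-out stays flat across these changes.

The compounds shown leave open whether a group of another kind on this aromatic carbon, such as an amine, a carboxylic acid or a longer alkyl chain, would move the read-out away from where these compounds sit. They also leave open whether a change elsewhere on the core of compound 1 would lower the number in this assay, since every step shown here falls on the aryl group.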